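The source may report more compounds than this note shows. Statements on the series, on what has been measured and on what is new or still open speak of the compounds shown alone.

Of the compounds shown here, three sharing one core have been measured in a functional assay for agonist activity at Alpha-1A adrenergic receptor (Homo sapiens); on this read-out lower numbers stand for an effect already at smaller amounts and higher numbers for an effect only at larger amounts of compound. Compound 1 `CS(=O)(=O)c1cc(Cl)ccc1NCC1=NCCN1` gives 513 nM in this assay, compound 2 `CSc1ccc(F)cc1NCC1=NCCN1` gives 2.29 nM, and compound 3 `CSc1ccc(C)cc1NCC1=NCCN1` gives 0.11 nM. Compound 3 therefore stands lowest of the three numbers: its nearest neighbour is compound 2, separated by a 21-fold lower number from compound 2 to compound 3 (1.32 log units; beyond the scatter), and compound 1 lies furthest away, its value far higher than that of compound 3.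

Compound 4 `COc1ccc(SC)c(NCC2=NCCN2)c1` differs from compound 3 in a single place: methoxy in place of methyl on an aromatic carbon. Within the data shown here, the only measured step at this position is the one from compound 2 to compound 3, and it was large, showing that this carbon is sensitive to what it carries. Among the measured compounds shown here, no measured pair, however, shows methoxy in place of methyl, so the guidance is indirect. For compound 4 a rise in this assay beyond the scatter is expected, a 9.1-fold higher number from compound 3 to compound 4 (0.96 log units; beyond the scatter). Compound 4 is accordingly estimated at 1 nM, with a range from 0.15 nM to 8 nM.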

Compound 4, half-maximal effective concentration: 1.59 nM
For compound 4 the middle estimate is 1.6-fold (0.20 log units) below the measured one, within the range that was stated.
By their numbers in this assay, from the lowest: compound 3; then compounds 4 and 2 (each within the scatter of the next); then compound 1.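

In this assay, among these compounds, methyl is no longer the only group tested against fluoro on this aromatic carbon, para to a methylsulfanyl group. Methoxy, with its added oxygen, gives a 14-fold higher number from compound 3 to compound 4 (1.16 log units; beyond the scatter) and so does not keep the low number seen with methyl. Fluoro and methoxy are not separated here, as a 1.4-fold lower number from compound 2 to compound 4 (0.16 log units; within the scatter) stays inside the usual scatter, so among these three groups only methyl stands apart, and nothing at hand explains this result.

Going by these compounds, whether the low number is particular to methyl or extends to ethyl, chloro or an amine on this carbon remains open. On these data alone, it is also open whether methyl would still stand apart from methoxy and fluoro if an ethylsulfanyl group replaced the methylsulfanyl group.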